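This account rests on a few compounds, and the source may have more. Where it says the series, first, only, none or still open, it means among the compounds named here.

Measured in an ADME assay on THP-1 cells (Homo sapiens) for cytotoxicity, read by flow cytometry and propidium iodide staining, with a stated time of 72 h; on this read-out lower numbers stand for stronger inhibition and higher numbers for weaker inhibition:
Compound 1 `Cc1ccc(S(=O)(=O)Cc2nc(C)n(C)c2[N+](=O)[O-])cc1`: 242000 nM
Compound 2 `Cc1nc(CS(=O)(=O)c2ccccc2)c([N+](=O)[O-])n1CCO`: > 768000 nM

Only compound 1 has a true number on this read-out. Compound 2 gives only a limit of the assay, > 768000 nM, and no number. That reading is the limit of > 768000 nM in this assay, at which 1 of the 2 values shown sits.

Compound 3 `Cc1ccc(S(=O)(=O)Cc2nc(C)n(CCO)c2[N+](=O)[O-])cc1` is the next compound to consider. It differs from compound 2 in one place: methyl in place of hydrogen on an aromatic carbon, so that phenyl becomes 4-methylphenyl. Going by the values given here, no step between measured compounds shows what this change does in this assay, so any expectation rests on little. Among the compounds with values here, compound 1, which also carries 4-methylphenyl, reads 242000 nM, and this is the only number available as a guide. A modest move towards lower numbers, meaning stronger inhibition, is therefore expected, though it may stay within the scatter. The expected change is an at least 1.5-fold lower number from compound 2 to compound 3 (0.18 log units; that floor lies within the scatter). Compound 3 may well return a limit too. As a number, compound 3 is estimated at 500000 nM, with an expected range of 220000 nM to 1100000 nM.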

Compound 3, half-maximal inhibitory concentration: 59000 nM
The estimate for compound 3 lay 8.5-fold (0.93 log units) above the measured number, outside the stated range (below it).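

Going by these compounds alone, the methyl group on the aromatic ring has a clear effect in this assay: the change from phenyl to 4-methylphenyl, para to a large group, gives an at least 13-fold lower number from compound 2 to compound 3 (1.11 log units; beyond the scatter), the first reading of this change. Going by these compounds, compound 2 gives a limit and not a number, so the true size of this step stays unknown and only its floor can be read: the limit of > 768000 nM in this assay, at which 1 of the 3 values shown sits. With 4-methylphenyl held in place, the chain on the aromatic nitrogen also counts, since hydroxymethyl in place of hydrogen on the saturated chain carbon bound to that nitrogen gives a 4.1-fold lower number from compound 1 to compound 3 (0.61 log units; beyond the scatter), which makes compound 3 the strongest inhibitor of the three in this read-out.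

The compounds shown leave open whether the effect belongs to methyl alone or would also appear with a chlorine atom, a methoxy group or a tert-butyl group on the same ring carbon. They also leave open how the read-out would respond to a longer chain on the aromatic nitrogen, or to an amine or a carboxylic acid in place of the hydroxyl group at the end of that chain.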